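The source may hold more compounds than are shown below. What is called first, only, known or untested is meant among the compounds shown, and "the series" means these compounds.

Measured compounds:
compound 1 `Cc1ccc(O)c(/C=N/NC(=S)N/N=C2\C(=O)Nc3ccc(C)cc32)c1`; in a functional assay on COS-7 cells (Chlorocebus aethiops) for inhibition, read by MTT assay (a higher number here means a weaker inhibitor, a lower number a stronger inhibitor), compound 1 gives > 50000 nM, a limit of the assay rather than a number.
compound 2 `Cc1ccc2c(c1)/C(=N/NC(=S)N/N=C/c1c(Cl)cccc1Cl)C(=O)N2`; in this assay compound 2 gives 3870 nM.

Compound 2 is the only compound with a numerical value in this assay; the other shown value is a limit (the limit of > 50000 nM in this assay, at which 1 of the 2 values shown sits). Going by the values given here, the one measured step, an at least 12-fold lower number from compound 1 to compound 2 (1.11 log units; beyond the scatter), shows that what sits on the carbon with a double bond to nitrogen matters strongly.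

Compound 3 `Cc1ccc2c(c1)/C(=N/NC(=S)N/N=C/c1ccccc1Br)C(=O)N2` differs from compound 2 by 2-bromophenyl in place of 2,6-dichlorophenyl on a carbon with a double bond to nitrogen. Both compound 2 and compound 3 carry a halogen-bearing phenyl at that position, so the change is smaller than the measured step. Only a modest change is expected, a 1.6-fold higher number from compound 2 to compound 3 (0.19 log units; within the scatter), probably towards a somewhat weaker inhibitor since one halogen is lost. Compound 3 is estimated at 6000 nM in this assay, within 2000 nM to 20000 nM.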

Compound 3, half-maximal inhibitory concentration: > 50000 nM
Compound 3 was reported as a limit; the forecaster's own chance of this, stated with the estimate: 15%; at least 8.3-fold (0.92 log units) between middle value and limit.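

The change to 2-bromophenyl in place of 2,6-dichlorophenyl on a carbon with a double bond to nitrogen gives an at least 12-fold higher number from compound 2 to compound 3 (1.11 log units; beyond the scatter), so in this assay a halogen on the phenyl is not enough by itself at this position. Compound 1 and compound 3 both stand at a limit, so the step between them cannot be read, and no order of 2-hydroxy-5-methylphenyl and 2-bromophenyl follows from it. Going by these compounds alone, only compound 2 gives a number so far: the limit of > 50000 nM in this assay, at which 2 of the 3 values shown sit.

The compounds shown do not separate the identity of the halogen from the number of halogens, which 2-chlorophenyl or 2,6-dibromophenyl on this carbon would address. As far as these compounds go, how a halogen-free group such as 2,6-dimethylphenyl or a pyridine ring behaves here also stays open.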